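Ester in place of the amide of compound 2

The source may report more compounds than this note shows. Statements on the series, on what has been measured and on what is new or still open speak of the compounds shown alone.

Compound 1 `NC(=O)c1cc(NC(=O)c2cnc(Cl)nc2C(F)(F)F)cc(C(F)(F)F)c1` gives 3000 nM in an assay on Jurkat cells for inhibition of cyclic AMP-dependent transcription factor ATF-1 (Homo sapiens); a higher number here means a weaker inhibitor, a lower number a stronger inhibitor. For compound 2 `CCCCNC(=O)c1cc(NC(=O)c2cnc(Cl)nc2C(F)(F)F)cc(C(F)(F)F)c1` this assay reports only a limit, > 10000 nM. Going by the values given here, the single measured step, an at least 3.3-fold higher number from compound 1 to compound 2 (0.52 log units; beyond the scatter), weakened inhibition, and compound 2 therefore stands at the weak end of the pair, at the limit of > 10000 nM in this assay, at which 1 of the 2 values shown sits. Compound 3 `CCOC(=O)c1cc(NC(=O)c2cnc(Cl)nc2C(F)(F)F)cc(C(F)(F)F)c1` differs from compound 2 by ethoxy in place of butylamino on a carbonyl carbon. Among the compounds with values here, no measured step covers an ester in this position, so the direction remains open. Within the data shown here, for compound 3 a number close to the limit is expected, the step of an at least 1.2-fold lower number from compound 2 to compound 3 (0.09 log units; that floor lies within the scatter) being an expectation that rests on no precedent. Compound 3 is estimated at 8000 nM, between 2500 nM and 30000 nM.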

Compound 3, half-maximal inhibitory concentration: 150 nM
Compound 3: the middle estimate sits 53-fold (1.73 log units) above what was measured; the measured number lies below the stated range.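

On this carbonyl carbon, change can strengthen inhibition as well as weaken it: ethoxy in place of amino gives a 20-fold lower number from compound 1 to compound 3 (1.30 log units; beyond the scatter) in this assay. Ethoxy in place of butylamino gives an at least 66-fold lower number from compound 2 to compound 3 (1.82 log units; beyond the scatter). That step is only a floor, since compound 2 stands at a limit: the limit of > 10000 nM in this assay, at which 1 of the 3 values shown sits.

The compounds shown leave open whether the gain belongs to the ester linkage or to the ethyl chain. A carboxylic acid, a methyl ester or a butyl ester on this carbonyl carbon would separate the two.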